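The source may hold more compounds than are shown below. What is called first, only, known or untested is meant among the compounds shown, and "the series" means these compounds.

Working notes on a small set of purine-based chloromethylbenzyl compounds tested for cytotoxicity in a functional assay on SK-MEL-2 cells (Homo sapiens) for cytotoxicity, read by sulforhodamine B assay, with a stated time of 48 h; on this read-out higher numbers stand for weaker inhibition of growth and lower numbers for stronger inhibition of growth. Compound 1 `ClCc1ccc(Cn2cnc3c(Cl)ncnc32)cc1` gives in this assay only > 100000 nM, which is a limit of the assay and not a number; this is the position described by the limit of > 100000 nM in this assay, at which 1 of the 3 values shown sits. Compound 2 `ClCc1ccccc1Cn1cnc2c(Cl)nc(Cl)nc21` gives 4360 nM in this assay. Compound 3 `ClCc1cccc(Cn2cnc3c(Cl)nc(Cl)nc32)c1` gives 4460 nM in this assay, and this value and that of compound 2 sit within the usual scatter of each other. Both compound 2 and compound 3 carry a second chloro group on the shared core that compound 1 lacks. Among the compounds with values here, no step between two measured compounds differing in a single place is available, so no measured step size can be quoted.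

Compound 4 `ClCc1ccc(Cn2cnc3c(Cl)nc(Cl)nc32)cc1` has not yet been measured. It differs from compound 1 by chloro in place of hydrogen on an aromatic carbon, in words chloro in place of hydrogen on an aromatic carbon, so that compound 4 carries the second chloro group that compound 2 and compound 3 also carry. Because compound 1 shows only the limit > 100000 nM, the step from compound 1 to compound 4 is expected to be a gain in growth inhibition of roughly an at least 20-fold lower number from compound 1 to compound 4 (1.30 log units; beyond the scatter). Compound 4 is therefore estimated at 5000 nM in this assay, with a range from 2000 nM to 20000 nM.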

Compound 4, concentration for total growth inhibition: 43700 nM
Estimate against measurement, compound 4: 8.7-fold (0.94 log units) below; measured number outside the range, above it.
By their numbers in this assay, from the lowest: compounds 2 and 3 (each within the scatter of the next); then compound 4. At a limit, above all of these: compound 1.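

In this assay, within the data shown here, chloro in place of hydrogen on an aromatic carbon, between two ring nitrogen atoms, gives an at least 2.2-fold lower number from compound 1 to compound 4 (0.35 log units; beyond the scatter), the first step that can be read across a single change. Compound 1 gives > 100000 nM, a limit of the assay and not a number, so the step shows the direction of the change while its full size cannot be read: the limit of > 100000 nM in this assay, at which 1 of the 4 values shown sits.

Carrying the same second chloro group as compound 2 and compound 3, compound 4 gives 43700 nM, while compound 2 gives 4360 nM and compound 3 gives 4460 nM, so the presence of this chloro group does not by itself bring compound 4 to the printed values of the other two.

Going by these compounds, it remains open how much of that gap follows the place of the chloromethyl group on the compounds that carry the second chloro group. Also open, on these data alone, is whether an amine or a methoxy group at the position of the new chloro group would give a comparable step in this assay.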